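This account rests on a few compounds, and the source may have more. Where it says the series, first, only, none or still open, it means among the compounds named here.

Compound 1 `O=c1cc(CSc2nc3ccccc3s2)oc2ccccc12` is the unsubstituted member of the first pair. In a functional assay on SW480 cells (Homo sapiens) for cytotoxicity, read by MTT assay, with a stated time of 72 h (on this read-out higher numbers stand for weaker inhibition and lower numbers for stronger inhibition), compound 1 gives only a limit of the assay, > 25000 nM. Compound 2 `O=c1cc(CSc2nc3ccccc3s2)oc2ccc(Cl)cc12` carries a chloro group on the shared core. In this assay compound 2 likewise gives only a limit, > 25000 nM. The change from compound 2 to compound 1 is hydrogen in place of chloro on an aromatic carbon, and the step it made, a step that the two limits leave unreadable from compound 2 to compound 1, cannot be read because of the limit of > 25000 nM in this assay, at which 3 of the 3 values shown sit.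

Compound 3 `Cc1nnc(SCc2cc(=O)c3cc(Cl)ccc3o2)o1` belongs to a second pair built on a different core; the difference between the two cores is not broken down here. In this assay compound 3 gives only a limit, > 25000 nM.

Compound 4 `Cc1nnc(SCc2cc(=O)c3ccccc3o2)o1` has not yet been measured. The change from compound 3 to compound 4 is hydrogen in place of chloro on an aromatic carbon, and it is the same change as that from compound 2 to compound 1, since the place of the leaving chloro and the entering hydrogen is described in the same words for both pairs. That earlier change left no readable step, because of the limit of > 25000 nM in this assay, at which 3 of the 3 values shown sit. The step from compound 3 to compound 4 is therefore expected to be a step that the limit leaves unreadable from compound 3 to compound 4, which rests only on the absence of any measurable effect in the first pair. For compound 4 the estimate in this assay is 40000 nM, with a range from 15000 nM to 120000 nM, and a limit rather than a number is the most likely outcome.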

Compound 4, half-maximal inhibitory concentration: > 25000 nM
Compound 4: a limit, no number (the forecaster's own chance of this, stated with the estimate: 85%); the middle value does not contradict the limit.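

In this assay compound 4 gives > 25000 nM, which is a limit and not a number. The step between compound 3 and compound 4 therefore cannot be read, because all the values stop at the same limit: the limit of > 25000 nM in this assay, at which 4 of the 4 values shown sit.

The compounds shown leave open whether hydrogen in place of chloro changes the result on either core, and how strongly any of the four compounds inhibits in this assay.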